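Working notes: methyl to methoxy in the series

A few compounds are considered here, and "the series" means these few. Any claim that something is new, unique, unknown or untested is made for them only; others in the source may bear on it.

Values from a functional assay on PC-3 cells (Homo sapiens) for cytotoxicity, read by MTT assay, with a stated time of 72 h (a higher number here means a weaker inhibitor, a lower number a stronger inhibitor), follow.
- compound 1 `CNC(=O)c1cc(Oc2ccc(NC(=O)c3cc(-c4ccc(C(F)(F)F)cc4)ncn3)cc2F)ccn1` gives > 100000 nM (a limit)
- compound 2 `CNC(=O)c1cc(Oc2ccc(NC(=O)c3cc(-c4ccc(Br)cc4)ncn3)cc2F)ccn1` gives > 100000 nM (a limit)
- compound 3 `CNC(=O)c1cc(Oc2ccc(NC(=O)c3cc(-c4ccc(C)cc4)ncn3)cc2F)ccn1` gives 40200 nM

Compound 3 alone carries a number. Compound 1 and compound 2 stand at the limit of > 100000 nM in this assay, at which 2 of the 3 values shown sit, and have no number. Compound 4 `CNC(=O)c1cc(Oc2ccc(NC(=O)c3cc(-c4ccc(OC)cc4)ncn3)cc2F)ccn1` differs from compound 3 in one group, methoxy in place of methyl on an aromatic carbon. The nearest measured changes are an at least 2.4-fold lower number from compound 1 to compound 3 (0.39 log units; beyond the scatter) and an at least 2.4-fold lower number from compound 2 to compound 3 (0.39 log units; beyond the scatter) and both are bounds only. Neither has methoxy entering, so they set no size for this change. Within the data shown here, with compound 3 at 40200 nM as the only number, no step beyond the scatter is expected in this assay. A result at the limit stays possible for compound 4. The estimated change is a 1.0-fold higher number from compound 3 to compound 4 (0.02 log units; within the scatter) as a rough guide. Compound 4 is expected at 42000 nM (estimated range 15000 nM to 100000 nM).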

Compound 4, half-maximal inhibitory concentration: 56200 nM
Estimate against measurement, compound 4: 1.3-fold (0.13 log units) below; the measured number falls inside the stated range.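

In this assay, methoxy in place of methyl on an aromatic carbon gives a change that stays within the scatter: a 1.4-fold higher number from compound 3 to compound 4 (0.15 log units; within the scatter). Against bromo and trifluoromethyl, only floors within the scatter can be read, an at least 1.7-fold lower number from compound 2 to compound 4 (0.25 log units; that floor lies within the scatter) and an at least 1.7-fold lower number from compound 1 to compound 4 (0.25 log units; that floor lies within the scatter), so neither step shows a real separation. Both floors rest on one limit: the limit of > 100000 nM in this assay, at which 2 of the 4 values shown sit.

As far as these compounds go, the true size of those two steps stays open. Also open, from the compounds shown here alone, is whether an amine or a carboxylic acid in this place would move the number beyond the scatter from that of compound 3.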